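A few compounds are considered here, and "the series" means these few. Any claim that something is new, unique, unknown or untested is made for them only; others in the source may bear on it.

Compound 2 `N#Cc1cccc(-c2cnc(C(=O)CCCCCCc3ccccc3)o2)c1` and compound 1 `COC(=O)c1cccc(-c2cnc(C(=O)CCCCCCc3ccccc3)o2)c1` share one core and differ only in a single group on an aromatic ring. In an assay (Rattus norvegicus) for inhibition of Fatty-acid amide hydrolase 1 (Homo sapiens) (a higher number here means a weaker inhibitor, a lower number a stronger inhibitor), compound 1 gives 12 nM, and compound 2 gives 15 nM. Going by the values given here, the one measured step, a 1.3-fold higher number from compound 1 to compound 2 (0.10 log units; within the scatter), lies within the scatter, so compound 2 stands beside compound 1 with no order between the two numbers. Compound 3 `Cc1cccc(-c2cnc(C(=O)CCCCCCc3ccccc3)o2)n1` arises from compound 2 through the change (6-methylpyridin-2-yl in place of 3-cyanophenyl on an aromatic carbon), placed next to the ring oxygen of the core. Among the compounds with values here, no measured step exchanges the whole aromatic group for a ring with a nitrogen in it; the step from compound 1 to compound 2 bears on it only loosely, showing that a change at this end of the molecule left the number within the scatter. A step of about a 1.3-fold lower number from compound 2 to compound 3 (0.10 log units; within the scatter) is therefore expected, with no direction favoured. Compound 3 is estimated in this assay at 12 nM, with a range from 3 nM to 50 nM.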

Compound 3, inhibition constant: 3.3 nM
Compound 3: the middle estimate sits 3.6-fold (0.56 log units) above what was measured, within the range that was stated.
By their numbers in this assay, from the lowest: compound 3; then compounds 1 and 2 (each within the scatter of the next).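

In this assay, putting 6-methylpyridin-2-yl in place of 3-cyanophenyl gives a 4.5-fold lower number from compound 2 to compound 3 (0.66 log units; beyond the scatter), the only step among these compounds that lies beyond the scatter. Going by these compounds alone, the earlier exchange of methoxycarbonyl for cyano stayed within the scatter, so this result is the first sign that the group on this aromatic carbon, next to the ring oxygen, can shift the number when the whole aromatic group is replaced. Nothing available here explains why the number moved.

The step changes the ring and its substituent at once, so the separate contributions of the ring nitrogen and the methyl group remain unresolved. A plain pyridin-2-yl group would separate the two, while an ethyl group, an amine or a carboxylic acid in place of the methyl would test how much that substituent can vary.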